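This account rests on a few compounds, and the source may have more. Where it says the series, first, only, none or still open, it means among the compounds named here.

Measured in a physicochemical assay for metabolic stability, read by HPLC and mass spectrometry, in phosphate buffer, at 37 degrees C, at pH 7.4; on this read-out higher numbers stand for a longer-lived compound and lower numbers for a shorter-lived compound:
compound 1 `N=C(N)NCc1cn(C[C@@H]2[C@H](NC(=O)/C(=N\OC3(C(=O)O)CC3)c3csc(N)n3)C(=O)N2S(=O)(=O)O)nn1` gives 89 h
compound 2 `Nc1nc(/C(=N/OC2(C(=O)O)CC2)C(=O)N[C@@H]2C(=O)N(S(=O)(=O)O)[C@@H]2CN2CCOC2=O)cs1` gives 400 h

Going by the values given here, compound 2 stands highest of the two numbers, the only step measured being a 4.5-fold higher number from compound 1 to compound 2 (0.65 log units; beyond the scatter). Compound 3 `Nc1nc(/C(=N/OC2(C(=O)O)CC2)C(=O)N[C@@H]2C(=O)N(S(=O)(=O)O)[C@H]2CN2CCOC2=O)cs1` keeps every atom and bond of compound 2: the two compounds have the same atoms and bonds and differ only in configuration as drawn: 1 of 3 stereo elements differ; a stereocentre at a saturated ring carbon is drawn R in compound 2 and S in compound 3. Among the compounds with values here, that single measured step exchanges one group for another and says nothing about configuration, so no measured step bears on the change at hand. With no guide in the data, the step expected is a 1.6-fold lower number from compound 2 to compound 3 (0.20 log units; within the scatter), held small and given a wide range. Compound 3 is therefore estimated at 250 h in this assay, within 100 h to 600 h.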

Compound 3, half-life: 450 h
For compound 3 the middle estimate is 1.8-fold (0.26 log units) below the measured one; the measured number falls inside the stated range.
By their numbers in this assay, from the lowest: compound 1; then compounds 2 and 3 (each within the scatter of the next).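

In this assay, drawing the stereocentre at a saturated ring carbon as R or S gives no readable difference: a 1.1-fold higher number from compound 2 to compound 3 (0.05 log units; within the scatter). The earlier step exchanged one group for another, whereas this pair shows that, with the group of 6 heavy atoms in place, this configuration leaves the half-life within the scatter. The comparison isolates this single centre: the fact that compounds 2 and 3 differ only in the configuration as drawn

As far as these compounds go, whether this holds with the group of 10 heavy atoms of compound 1 remains open. So does its outcome with a primary amine or a longer chain on the saturated chain carbon.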